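Sulfonyl aryl swap in the piperazine acetamide series

The source may hold more compounds than are shown below. What is called first, only, known or untested is meant among the compounds shown, and "the series" means these compounds.

Going by the values given here, compound 3 `O=C(CN1CCN(S(=O)(=O)c2cccnc2)CC1)Nc1ccccc1F` gives 20300 nM in an in vitro assay on HEK ts201 cells for negative allosteric modulation of Neuronal acetylcholine receptor; alpha4/beta2 (Homo sapiens), read by fluorescence and calcium flux, with a stated time of 1.5 s (on this read-out lower numbers stand for stronger inhibition and higher numbers for weaker inhibition), and holds the highest of the three numbers measured so far. Its nearest neighbour is compound 1 `O=C(CN1CCN(S(=O)(=O)c2ccc(F)cc2)CC1)Nc1ccc(F)cc1`, which gives 13800 nM in this assay, a gap within the scatter; the furthest is compound 2 `O=C(CN1CCN(S(=O)(=O)c2ccccc2F)CC1)Nc1ccccc1F`, which gives 8000 nM in this assay. Among the compounds with values here, the one single-point step on record that touches the sulfonyl aryl is a 2.5-fold higher number from compound 2 to compound 3 (0.40 log units; beyond the scatter), a modest worsening.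

Compound 4 `O=C(CN1CCN(S(=O)(=O)c2ccccc2)CC1)Nc1ccccc1F` differs from compound 3 as follows: phenyl in place of pyridin-3-yl on a sulfonyl sulfur. Within the data shown here, this move undoes the heteroaryl part of the step from compound 2, while the fluorine of compound 2 is not restored, so a partial reversal of that step is the only guide. A lower number than compound 3 is therefore expected, but of modest size and not necessarily beyond the scatter; the estimate for compound 4 in this assay is 11000 nM, with a range from 4500 nM to 27000 nM. The expected step is a 1.8-fold lower number from compound 3 to compound 4 (0.27 log units; within the scatter).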

Compound 4, half-maximal inhibitory concentration: 4100 nM
Compound 4: middle estimate off by 2.7-fold (0.43 log units), on the high side; the whole stated range lies above it.
By their numbers in this assay, from the lowest: compounds 4, 2, 1 and 3 (each within the scatter of the next, the first and the last beyond it).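

On the sulfonyl sulfur, phenyl in place of pyridin-3-yl gives a 5.0-fold lower number from compound 3 to compound 4 (0.69 log units; beyond the scatter) in this assay and isolates the swap of the ring nitrogen for carbon, which the earlier step from compound 2 could not do, as it also removed a fluoro. Hydrogen in place of fluoro on an aromatic carbon gives a 2.0-fold lower number from compound 2 to compound 4 (0.29 log units; within the scatter) and so places no order on compound 2 and compound 4, which means the fluoro is not required to reach the lower numbers in this small set. Nothing on record explains the gap between the phenyl and pyridin-3-yl compounds.

Open, going by these compounds, is whether a methoxy or chloro group on the phenyl moves the number beyond the scatter. Also open, on these data alone, is whether a non-aromatic group on the sulfonyl sulfur, such as methyl or cyclopropyl, keeps the number seen for compound 4.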